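The source may report more compounds than this note shows. Statements on the series, on what has been measured and on what is new or still open speak of the compounds shown alone.

Three members of the series have been run in a functional assay on WM 266-4 cells (Homo sapiens) for inhibition, read by MTT assay, with a stated time of 24 h; a higher number here means a weaker inhibitor of growth, a lower number a stronger inhibitor of growth. Compound 1 `COc1ccc(C2=NN(C(=O)C3COc4ccccc4O3)C(c3ccc(F)cc3)C2)cc1` gives 6190 nM in this assay. Compound 2 `O=C(c1ccc2c(c1)OCCO2)N1N=C(c2ccccc2)CC1c1ccc(F)cc1` gives 5210 nM in this assay, and compound 3 `O=C(c1ccc2c(c1)OCCO2)N1N=C(c2ccccc2)CC1c1ccccc1` gives 1370 nM in this assay. Compounds 2 and 3 differ in one place, (hydrogen in place of fluoro on an aromatic carbon), and that change gave a 3.8-fold lower number from compound 2 to compound 3 (0.58 log units; beyond the scatter). Compound 1 and compound 2 sit on different cores; the difference between the two cores is not broken down here, and the values of compound 1 and compound 2 in this assay lie within the scatter of each other. Compound 4 `COc1ccc(C2=NN(C(=O)C3COc4ccccc4O3)C(c3ccccc3)C2)cc1` is not yet measured. It is related to compound 1 by the same change as the one already measured, (hydrogen in place of fluoro on an aromatic carbon), at the same place. On the core of compound 1 the step is expected to be a 3.4-fold lower number from compound 1 to compound 4 (0.54 log units; beyond the scatter), resting on the size of a 3.8-fold lower number from compound 2 to compound 3 (0.58 log units; beyond the scatter) in the other pair; whether it carries over to this core is open until compound 4 is measured. In this assay compound 4 is therefore estimated at 1800 nM, with a range from 700 nM to 4500 nM.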

Compound 4, concentration for 50% growth inhibition: 6310 nM
The estimate for compound 4 lay 3.5-fold (0.54 log units) below the measured number; measured number above the stated range.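

In this assay, hydrogen in place of fluoro on the core of compound 1 gave a 1.0-fold higher number from compound 1 to compound 4 (0.01 log units; within the scatter), so the size of this step did not carry over from one core to the other: the same change on two cores in this assay, a 3.8-fold lower number (0.58 log units; beyond the scatter) from compound 2 to compound 3 and a 1.0-fold higher number (0.01 log units; within the scatter) from compound 1 to compound 4, 3.9-fold (0.59 log units) apart, beyond the scatter of two such steps

The earlier step, a 3.8-fold lower number from compound 2 to compound 3 (0.58 log units; beyond the scatter), therefore holds for that pair and cannot be used on its own to predict the same change on another core in this series. For the compounds shown here, with only two pairs, the data do not show which feature of the two cores goes with the different outcomes, nor how the 4-fluorophenyl to phenyl change would behave on a third core.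

The compounds shown leave open how a chloro group, an amine or a carboxylic acid on the same aromatic carbon would read on either core. Going by these compounds, all four values come from this assay, so whether the difference between the two pairs also appears in other cells remains open.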